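Replacing cyano with trifluoromethoxy: what clearance to expect

This account rests on a few compounds, and the source may have more. Where it says the series, first, only, none or still open, it means among the compounds named here.

In an ADME assay on microsomes from liver (Mus musculus, strain CD1) for metabolic stability, read by HPLC, using NADPH, with a stated time of 30 min (on this read-out higher numbers stand for fast clearance and lower numbers for slow clearance), compound 1 (`COc1cccc(NC(=O)c2nnn(Cc3ccncc3)c2N)c1`) gives 0.7 mL.min-1.g-1 and compound 2 (`COc1cccc(NC(=O)c2nnn(CC3CCN(C(C)=O)CC3)c2N)c1`) gives 0.7 mL.min-1.g-1, which amounts to no change at the digits printed from compound 1 to compound 2 (within the scatter). Compound 3 (`COc1cccc(NC(=O)c2nnn(Cc3ccc(C#N)cc3)c2N)c1`) stands highest of the three at 2.5 mL.min-1.g-1. It is reached by a 3.6-fold higher number from compound 1 to compound 3 (0.55 log units; beyond the scatter) and equally by a 3.6-fold higher number from compound 2 to compound 3 (0.55 log units; beyond the scatter).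

Compound 4 (`COc1cccc(NC(=O)c2nnn(Cc3ccc(OC(F)(F)F)cc3)c2N)c1`) keeps the shared core of compound 3 and carries trifluoromethoxy in place of cyano on an aromatic carbon, para to a large group: trifluoromethoxy in place of cyano on an aromatic carbon. Within the data shown here, no measured pair makes this exchange directly. The two steps that reach compound 3 replace the whole group on the saturated chain carbon, so they bear on the new step only indirectly. They do show that a change in that group can move the number in this assay, as in a 3.6-fold higher number from compound 1 to compound 3 (0.55 log units; beyond the scatter). Among the measured compounds shown here, with no measurement of the new group, a small upward move is expected, no larger than those steps, and it may not clear the scatter. The expected change is a 1.8-fold higher number from compound 3 to compound 4 (0.26 log units; within the scatter). For compound 4 the estimated clearance is 4.5 mL.min-1.g-1, with an expected range from 1.8 mL.min-1.g-1 to 10 mL.min-1.g-1.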

Compound 4, intrinsic clearance in microsomes: 2.9 mL.min-1.g-1
Estimate against measurement, compound 4: 1.6-fold (0.19 log units) above; low and high end bracket the measured number.
By their numbers in this assay, from the lowest: compounds 1 and 2 (each within the scatter of the next); then compounds 3 and 4 (each within the scatter of the next).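

In this assay, the exchange on an aromatic carbon, para to a large group, gives a 1.2-fold higher number from compound 3 to compound 4 (0.06 log units; within the scatter), so the numbers for trifluoromethoxy, with 5 heavy atoms, and cyano, with 2 heavy atoms, lie within the scatter of each other. The earlier steps shown here replaced the whole group on the saturated chain carbon, whereas this one alters only the group on the aromatic carbon and shows that these two groups cannot be told apart at this position in this read-out, despite their different heavy-atom counts and atom types. The information available offers no explanation for this result.

From the compounds shown here alone, it remains open whether this position would respond in the same way to an amine, a carboxylic acid, or a longer alkyl chain, or whether the two groups compared here simply happen to give similar numbers. The compounds shown also leave open what a plain hydrogen at this aromatic carbon would give, and whether trifluoromethoxy on another carbon of the same ring would fall within the scatter of compound 4.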